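This account rests on a few compounds, and the source may have more. Where it says the series, first, only, none or still open, it means among the compounds named here.

In a functional assay on KMS-11 cells (Homo sapiens) for antiproliferative activity, read by CellTiter-Glo, with a stated time of 72 h (on this read-out lower numbers stand for stronger inhibition and higher numbers for weaker inhibition), two compounds have values so far
Compound 1 `COc1ccc(C(=O)N(Cc2ccncc2)Cc2cccc(OCC3CCN(C(=O)OC(C)(C)C)CC3)c2)cc1` gives 5100 nM
Compound 2 `COc1ccc(C(=O)N(Cc2ccncc2)Cc2cccc(OCC3CCCCC3)c2)cc1` gives 19700 nM

Compound 2 stands highest of the two, and the gap down to compound 1 lies beyond the usual scatter. Compound 3 `COc1ccc(C(=O)N(Cc2ccncc2)Cc2cccc(OCc3ccc(F)cc3)c2)cc1` has yet to be measured and carries 4-fluorophenyl in place of cyclohexyl on a saturated chain carbon bound to an oxygen on an aromatic ring in comparison with compound 2. Among the measured compounds shown here, no measured step covers this change, so only a modest step toward lower numbers is expected in this assay for now. The expected move is a 2.0-fold lower number from compound 2 to compound 3 (0.29 log units; within the scatter) on this estimate. Compound 3 is estimated at 10000 nM with an expected range from 3500 nM to 30000 nM in this reading.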

Compound 3, half-maximal inhibitory concentration: 22700 nM
Compound 3: the middle estimate sits 2.3-fold (0.36 log units) below what was measured, and the stated range covers the measured number.
By their numbers in this assay, from the lowest: compound 1; then compounds 2 and 3 (each within the scatter of the next).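

In this assay, placing 4-fluorophenyl in place of cyclohexyl on a saturated chain carbon bound to an oxygen on an aromatic ring gives a 1.2-fold higher number from compound 2 to compound 3 (0.06 log units; within the scatter). At this position, then, an aromatic ring carrying fluorine and a non-aromatic ring of carbon only cannot be told apart on this read-out. Nothing available accounts for this result.

Still open, going by these compounds, is whether plain phenyl would read like 4-fluorophenyl here. Also open, on these data alone, is whether an amine, a carboxylic acid or a longer chain at this position would shift the number beyond the scatter.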